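The source may report more compounds than this note shows. Statements on the series, on what has been measured and on what is new or still open speak of the compounds shown alone.

Compound 1 `CC1CC1COc1cccc2ccc(N)nc12` gives 1640 nM in an assay on cells with melanin-concentrating hormone receptor 1 (Homo sapiens) as the target, read by radioligand binding; a lower number here means a stronger inhibitor, a higher number a weaker inhibitor.
Compound 2 `CC(CC(C)(C)C)Oc1cccc2ccc(N(C)C)nc12` gives > 2000 nM in this assay; this is a limit of the assay, not a number.
Compound 3 `CNc1ccc2cccc(OC(C)CC(C)(C)C)c2n1` gives 310 nM in this assay.

Compound 1 thus has the highest of the two numbers given here, and the nearest measured neighbour is compound 3, which sits a good deal lower. Among the measured compounds shown here, the only single change measured is that from compound 2 to compound 3, an at least 6.4-fold lower number from compound 2 to compound 3 (0.80 log units; beyond the scatter), a change at the nitrogen attached to the shared core.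

Compound 4 `Nc1ccc2cccc(OCC3CCCO3)c2n1` differs from compound 1 only in the group carried on the ether side chain: oxolan-2-yl in place of 2-methylcyclopropyl on a saturated chain carbon bound to an oxygen on an aromatic ring. For the measured compounds named here, no measured step touches this side chain; the one step known, from compound 2 to compound 3, is at a different place and says nothing about swapping one small ring for another on the chain. With nothing to lean on, no shift beyond the scatter is expected for compound 4 in this assay, and the estimated step is a 1.1-fold lower number from compound 1 to compound 4 (0.04 log units; within the scatter). Compound 4 is therefore expected to give about 1500 nM, with a range of 400 nM to 5000 nM.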

Compound 4, half-maximal inhibitory concentration: > 2000 nM
Compound 4 gave a limit, no number; the forecaster's own chance of this, stated with the estimate: 20%; at least 1.3-fold (0.12 log units) between middle value and limit.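

Among the compounds shown here, this is the only measured change on the ether side chain: oxolan-2-yl in place of 2-methylcyclopropyl gives an at least 1.2-fold higher number from compound 1 to compound 4 (0.08 log units; that floor lies within the scatter). The swap brings in a ring oxygen and with it one hydrogen-bond acceptor, yet it gives no gain in this assay, although a true loss is not established either. Compound 4 carries a limit, not a number, so the real size of this step cannot be read: the limit of > 2000 nM in this assay, at which 2 of the 4 values shown sit.

From the compounds shown here alone, what stays open is whether the ring oxygen or the change of ring matters, and a cyclopentyl group in the same place would separate the two. How a longer chain or an amine on this saturated chain carbon would compare with compound 1 is also unknown from the compounds shown.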